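Hydroxy in Place of Hydrogen on a Carbonyl Carbon

The source may report more compounds than this note shows. Statements on the series, on what has been measured and on what is new or still open speak of the compounds shown alone.

Compound 1 `CC1=CCC([C@]2(C)Cc3c(O)cc(C(=O)O)cc3O2)CC1`: 730000 nM
Compound 2 `COc1cc(C=O)cc2c1C[C@@](C)(C1CC=C(C)CC1)O2`: > 1040000 nM

In a functional assay on the whole organism for inhibition, with Homo sapiens as the target, read by hemolysis (a lower number here means a stronger inhibitor, a higher number a weaker inhibitor), compound 1 gives 730000 nM. For compound 2 only a limit is known, > 1040000 nM; it stands at the limit of > 1040000 nM in this assay, at which 1 of the 2 values shown sits. Compound 3 `COc1cc(C(=O)O)cc2c1C[C@@](C)(C1CC=C(C)CC1)O2` differs from compound 2 by hydroxy in place of hydrogen on a carbonyl carbon. Going by the values given here, no measured pair covers this change. Compound 1 also carries the carboxy group and gives 730000 nM, so a move toward stronger inhibition from compound 2 to compound 3 is expected, an at least 1.3-fold lower number from compound 2 to compound 3 (0.11 log units; that floor lies within the scatter). Compound 3 is expected to reach 800000 nM, within 300000 nM to 2000000 nM.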

Compound 3, half-maximal inhibitory concentration: > 1000000 nM
Compound 3 gave a limit, no number; the forecaster's own chance of this, stated with the estimate: 40%; middle value at least 1.2-fold (0.09 log units) away from the limit.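

In this assay compound 3 gives only a limit, > 1000000 nM, and not a number. Compound 2 also gives only a limit, so the step from formyl to carboxy cannot be read. With methyl in place of hydrogen on an oxygen on an aromatic ring, the comparison shows an at least 1.3-fold higher number from compound 1 to compound 3 (0.13 log units; that floor lies within the scatter), so the carboxy group alone does not give compound 3 a readable value.

The compounds shown leave open whether an amide or a methyl ester on this carbonyl carbon would give a readable number. As far as these compounds go, how far the true value of compound 3 lies from its limit also stays open.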